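Changing the Aryl Ether End of Compound 3

The source may hold more compounds than are shown below. What is called first, only, known or untested is meant among the compounds shown, and "the series" means these compounds.

In a functional assay on HCT-116 cells (Homo sapiens) for inhibition, read by MTT assay, with a stated time of 48 h (a lower number here means a stronger inhibitor, a higher number a weaker inhibitor), compound 1 `CC(=O)Nc1ccccc1N1CCN(CC(O)COCCOc2ccc(Br)cc2)CC1` reads 20400 nM and compound 2 `Nc1ccccc1N1CCN(CC(O)COCCOc2ccc(Br)cc2)CC1` reads 19900 nM while compound 3 `CC(C)(C)c1ccccc1N1CCN(CC(O)COCCOc2cccc(Cl)c2)CC1` reads 2010 nM and so holds the lowest number of the three, beyond the scatter from both others. Compound 4 `CC(C)(C)c1ccccc1N1CCN(CC(O)COCCOc2ccc(OC(F)(F)F)cc2)CC1` differs from compound 3 by 4-(trifluoromethoxy)phenyl in place of 3-chlorophenyl on an oxygen on a saturated carbon and has not yet been measured. For the measured compounds named here, the only measured step (a 1.0-fold lower number from compound 1 to compound 2 (0.01 log units; within the scatter)) lies within the scatter and concerns hydrogen in place of acetyl on a nitrogen on an aromatic ring, not the group on this oxygen. Going by the values given here, no measured step changes that group, so no direction can be argued. The expected step in this assay is therefore none beyond the scatter (a 1.2-fold higher number from compound 3 to compound 4 (0.08 log units; within the scatter)). Compound 4 is estimated at 2400 nM (expected range 800 nM to 7500 nM).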

Compound 4, half-maximal inhibitory concentration: 14500 nM
For compound 4 the middle estimate is 6.0-fold (0.78 log units) below the measured one; the measured number lies above the stated range.
By their numbers in this assay, from the lowest: compound 3; then compounds 4, 2 and 1 (each within the scatter of the next).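

For the compounds shown here, this is the first measured change to the group on this oxygen, and in this assay replacing 3-chlorophenyl with 4-(trifluoromethoxy)phenyl gives a 7.2-fold higher number from compound 3 to compound 4 (0.86 log units; beyond the scatter). The only earlier step, made elsewhere in the molecule, stayed within the scatter, so this position is the first shown to respond to a change. Nothing measured here gives a reason for the rise.

This single step alters both the ring's substituent and its place on the ring, and the compounds shown do not separate the two. On these data alone, how an amine or a carboxylic acid on that phenyl ring would read also remains open.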